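Arylidene thiazolidinone series: cytotoxicity notes before compound 4

The source may hold more compounds than are shown below. What is called first, only, known or untested is meant among the compounds shown, and "the series" means these compounds.

Measured so far:
compound 1 `Cc1ccc(N2C(=O)CS/C2=N\c2csc(-c3ccc(Cl)cc3)c2)cc1` — > 50000 nM
compound 2 `CN(C)c1ccc(N2C(=O)CS/C2=N\c2csc(-c3ccc(Cl)cc3)c2)cc1` — > 50000 nM
compound 3 `CN(C)c1ccc(/C=C2\S/C(=N\c3nc(-c4ccc(Cl)cc4)cs3)NC2=O)cc1` — 100 nM

Three compounds have been run in a functional assay on MCF7 cells (Homo sapiens) for cytotoxicity, read by MTT assay, with a stated time of 72 h; on this read-out lower numbers stand for stronger inhibition and higher numbers for weaker inhibition. For compound 1 the reported > 50000 nM is a limit of the assay, not a number. For compound 2 the reported > 50000 nM is likewise a limit. Among the compounds with values here, compound 3 gives 100 nM, the only number in the set. How the core of compound 3 differs from the core of compound 2 is not broken down here.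

Compound 2 and compound 1 differ by methyl in place of dimethylamino on an aromatic carbon. The step that the two limits leave unreadable from compound 2 to compound 1 cannot be read because of the limit of > 50000 nM in this assay, at which 2 of the 3 values shown sit.

Compound 4 `Cc1ccc(/C=C2\S/C(=N\c3nc(-c4ccc(Cl)cc4)cs3)NC2=O)cc1` awaits measurement. It differs from compound 3 by methyl in place of dimethylamino on an aromatic carbon, the same change as from compound 2 to compound 1 at the same place. The earlier step gives no size to carry over. The step of a 4.0-fold higher number from compound 3 to compound 4 (0.60 log units; beyond the scatter) is expected as a wide-range guess resting on compound 3 at 100 nM. Compound 4 is therefore estimated at 400 nM, with an expected range from 60 nM to 5000 nM.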

Compound 4, half-maximal inhibitory concentration: 400 nM
Estimate against measurement, compound 4: no gap at the digits printed, and the stated range covers the measured number.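

In this assay, replacing dimethylamino with methyl on the aromatic carbon, on the core shared by compound 3 and compound 4, gives a 4.0-fold higher number from compound 3 to compound 4 (0.60 log units; beyond the scatter). On these data alone, the same change on the other core, from compound 2 to compound 1, cannot be read because both compounds sit at a limit rather than a number: the limit of > 50000 nM in this assay, at which 2 of the 4 values shown sit. The series therefore gives a size for this change on one core only, and it does not show whether the change keeps its size or even its direction on the core of compound 2, so a transfer between the two cores remains untested by these values.

Still open is how an amine such as morpholine, a carboxylic acid or a longer chain such as butyl would read at the same place on the core of compound 3, where only dimethylamino and methyl are shown. Also open, as far as these compounds go, is whether any group on the core of compound 2 gives a measured number rather than a limit.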